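From One Fluorine to Two Chlorines on the Benzyl Ring

This account rests on a few compounds, and the source may have more. Where it says the series, first, only, none or still open, it means among the compounds named here.

In an ADME assay on A549 cells (Homo sapiens) for cytotoxicity, read by resazurin assay, with a stated time of 48 h (a higher number here means that more compound is tolerated, a lower number that less compound is tolerated), the measured compounds give:
compound 1, `CCNc1ccc(NC(=O)c2cc(Cl)ccc2O)c(Cl)c1`: 30200 nM
compound 2, `CC(C)Nc1ccc(NC(=O)c2cc(Cl)ccc2O)c(Cl)c1`: 11000 nM
compound 3, `O=C(Nc1ccc(NCc2ccc(F)cc2)cc1Cl)c1cc(Cl)ccc1O`: 54400 nM

Compound 3 stands highest of the three, though one of its two gaps stays within the scatter, a 1.8-fold higher number from compound 1 to compound 3 (0.26 log units; within the scatter), while the other is larger, a 4.9-fold higher number from compound 2 to compound 3 (0.69 log units; beyond the scatter). Compound 4, `O=C(Nc1ccc(NCc2cc(Cl)cc(Cl)c2)cc1Cl)c1cc(Cl)ccc1O`, carries 3,5-dichlorophenyl in place of 4-fluorophenyl on a saturated chain carbon bound to a nitrogen on an aromatic ring. The steps seen so far all change the group on the nitrogen on the aromatic ring: a 2.7-fold lower number from compound 1 to compound 2 (0.44 log units; beyond the scatter) and a 4.9-fold higher number from compound 2 to compound 3 (0.69 log units; beyond the scatter) are modest, a 1.8-fold higher number from compound 1 to compound 3 (0.26 log units; within the scatter) is within the scatter. None of them swaps one halogen pattern for another on the same phenyl, so they bear only loosely on this step. Compound 4 is therefore expected to show a 1.4-fold lower number from compound 3 to compound 4 (0.13 log units; within the scatter), no step beyond the scatter. The estimate for compound 4 is 40000 nM, within 15000 nM to 100000 nM.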

Compound 4, half-maximal cytotoxic concentration: 13300 nM
Compound 4: middle estimate off by 3.0-fold (0.48 log units), on the high side; measured number outside the range, below it.
By their numbers in this assay, from the lowest: compounds 2 and 4 (each within the scatter of the next); then compounds 1 and 3 (each within the scatter of the next).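

The earlier steps shown here changed the whole group on the nitrogen, whereas this one shows that changing only the halogens on the benzyl ring also moves the number in this assay, with a 4.1-fold lower number from compound 3 to compound 4 (0.61 log units; beyond the scatter). A benzyl group alone therefore does not keep the number high: there is a 1.2-fold higher number from compound 2 to compound 4 (0.08 log units; within the scatter), and a 2.3-fold lower number from compound 1 to compound 4 (0.36 log units; beyond the scatter). Nothing measured here accounts for the change.

As far as these compounds go, it remains open whether losing the fluorine or gaining the chlorines matters more. A 3-chlorobenzyl or 4-chlorobenzyl group could help separate the two.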